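The compounds below may be only part of what the source reports. "The series", "measured", "known", "first", "only" and "open" are said of these compounds alone.

Of the compounds shown here, three have been read so far in an ADME assay on Vero cells (Chlorocebus sabaeus) for cytotoxicity, read by resazurin assay, with a stated time of 24 h; on this read-out higher numbers stand for lower toxicity in this test and lower numbers for higher toxicity in this test. Compound 1 `CCCCO[C@@H]1C=CC(=O)[C@@H](COC(=O)C(C)(C)C)O1` gives 42500 nM, the highest of the three numbers. Compound 2 `CC(=O)OC[C@H]1O[C@H](OCCC(C)C)C=C([C@H](O)c2ccc([N+](=O)[O-])cc2)C1=O` gives 14300 nM and compound 3 `Cc1ccc(S(=O)(=O)OC[C@H]2O[C@H](OC(C)C)C=CC2=O)cc1` gives 13400 nM, and each of these lies beyond the scatter from compound 1. Compound 4 `CC(C)CO[C@@H]1C=CC(=O)[C@@H](COC(=O)C(C)(C)C)O1` keeps the core of compound 1 and alters only the chain: isopropyl in place of propyl on a saturated chain carbon bound to an oxygen on a saturated carbon. This places isopropyl in place of propyl on a saturated chain carbon bound to an oxygen on a saturated carbon, with the same atoms joined differently. Among the measured compounds shown here, no two measured compounds differ in one place, so the data give no direct measure of such a change. Since the change is so small, compound 4 is expected to stay close to compound 1 at 42500 nM, with no firm direction. The estimated step is a 1.1-fold lower number from compound 1 to compound 4 (0.05 log units; within the scatter), which is expected to lie within the scatter. For compound 4 the estimated half-maximal cytotoxic concentration is 38000 nM, with an expected range from 20000 nM to 70000 nM.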

Compound 4, half-maximal cytotoxic concentration: 28200 nM
Estimate against measurement, compound 4: 1.3-fold (0.13 log units) above; the range from low to high includes it.
By their numbers in this assay, from the lowest: compounds 3, 2, 4 and 1 (each within the scatter of the next, the first and the last beyond it).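

In this assay, isopropyl in place of propyl on a saturated chain carbon bound to an oxygen on a saturated carbon gives a 1.5-fold lower number from compound 1 to compound 4 (0.18 log units; within the scatter) as the first direct reading of a change in one place among these compounds. With the core of compound 1 kept and the same atoms of the chain joined differently, the read-out stays within the usual scatter of repeated measurements, so this single step gives no direction at this position. No measurement on hand offers an explanation for this result.

The compounds shown leave open whether a longer chain such as hexyl, or a chain ending in an amine, would also stay this close to compound 1 at the same place. They also leave open how a carboxylic acid in place of the ester of compound 1 would read.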